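Cytotoxicity notes: from compound 3 to compound 4

A few compounds are considered here, and "the series" means these few. Any claim that something is new, unique, unknown or untested is made for them only; others in the source may bear on it.

Three compounds have been run in an ADME assay on HEK-293T cells (Homo sapiens) for cytotoxicity, with a stated time of 48 h; on this read-out higher numbers stand for lower toxicity in this test and lower numbers for higher toxicity in this test. Compound 1 `CCc1ncnc(NC(C)c2ccc3ccccc3n2)c1Cl` reaches only the limit > 10000 nM. Compound 2 `CCc1ncnc(NC(C)c2sc3ccccc3c2C)c1Cl` likewise stops at the limit > 10000 nM. Compound 3 `CCC(Nc1cc(C)ncn1)c1ccc(Oc2ccc(F)cc2)cc1` also gives no number but the limit > 10000 nM. Going by the values given here, compound 3 therefore stands where every value so far sits, namely at the limit of > 10000 nM in this assay, at which 3 of the 3 values shown sit, and no step between measured compounds can be sized. Compound 4 `CCc1ncnc(NC(CC)c2ccc(Oc3ccc(F)cc3)cc2)c1Br` differs from compound 3 in one place: 5-bromo-6-ethylpyrimidin-4-yl in place of 6-methylpyrimidin-4-yl on an amine nitrogen. Among the compounds with values here, with no measured step to lean on, the step from compound 3 to compound 4 is expected to be none beyond the scatter, an expected step that the limit leaves unreadable from compound 3 to compound 4. Compound 4 is accordingly expected to land at or near the limit in this assay, with an estimate of 12000 nM, ranging from 5000 nM to 40000 nM.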

Compound 4, half-maximal cytotoxic concentration: > 10000 nM
Compound 4 ended at the assay's limit; the forecaster's own chance of this, stated with the estimate: 70%; the middle value lies beyond the limit too.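

No step can be read from compound 3 to compound 4, since both values are limits and not numbers: the limit of > 10000 nM in this assay, at which 4 of the 4 values shown sit.

The compounds shown leave open whether 5-bromo-6-ethylpyrimidin-4-yl in place of 6-methylpyrimidin-4-yl changes cytotoxicity at all.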